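A few compounds are considered here, and "the series" means these few. Any claim that something is new, unique, unknown or untested is made for them only; others in the source may bear on it.

Measured so far in a functional assay on the whole organism (strain albino) with Mus musculus as the target, with a stated time of 0.5 h; a higher number here means that more compound is needed for the effect, a lower number that less compound is needed:
Compound 1 `COc1ccc(C2CC(Nc3nc4ccc(C)cc4s3)=NN2C(C)=O)cc1`: 39.4 umol/kg
Compound 2 `COc1ccc(C2CC(Nc3nc4ccccc4s3)=NN2C(C)=O)cc1`: "not determined" (no result reported)

Only one of these two entries is a number. Compound 2 reads "not determined" (no result reported), so it has no place on the dose scale and cannot be called better or worse than compound 1. It gives no starting point from which to measure a change.

The next structure is compound 3 `COc1ccc(C2CC(Nc3nc4ccc(Cl)cc4s3)=NN2C(C)=O)cc1`, which has not yet been measured. The structural change is chloro in place of hydrogen on an aromatic carbon. In words, chloro takes the place of hydrogen on an aromatic carbon.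

Among the compounds with values here, no step between two measured compounds exists here, so the size of this change cannot be read from earlier data. Within the data shown here, the only available reference is compound 1, at 39.4 umol/kg. Nothing in these data favours a direction, so the expectation in this assay is a result that stays within the usual scatter of that reference, neither clearly higher nor clearly lower. The range is kept wide because it rests on a single number. For compound 3 the expected dose is 40 umol/kg, with an estimated range from 16 umol/kg to 95 umol/kg.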

Compound 3, dose for half-maximal effect: 97.3 umol/kg
Compound 3: the middle estimate sits 2.4-fold (0.39 log units) below what was measured; measured number outside the range, above it.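

In this assay, replacing methyl with chloro gives a 2.5-fold higher number from compound 1 to compound 3 (0.39 log units; beyond the scatter). The step is modest but lies beyond the scatter, so this aromatic carbon, meta to a fused ring and para to a fused ring, is not indifferent to the group it carries: here more of the chloro compound is needed for the effect. Compound 2, which carries hydrogen at this carbon, has no number, so the step from hydrogen to chloro cannot be read, and the data compare only methyl with chloro; nothing measured alongside these doses explains the difference.

Within the data shown here, with only two numbers on the dose scale, this single step cannot establish a trend across groups at this carbon, and it remains unknown whether the same difference would hold if the rest of the molecule changed. Also open, on these data alone, is where a fluoro group, an amine or a carboxylic acid on the same aromatic carbon would fall relative to methyl and chloro.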